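The source may report more compounds than this note shows. Statements on the series, on what has been measured and on what is new or still open speak of the compounds shown alone.

Measured compounds:
- compound 1, `CC1(c2ccc(NC(c3ccc(F)cc3)c3nnnn3C(C)(C)C)cc2)NC(=O)c2ccccc2N1`: "not determined" (no result reported)
- compound 2, `CCCCCNc1nc(NCCCCC)nc(Nc2ccc(C3(C)NC(=O)c4ccccc4N3)cc2)n1`: > 400000 nM
- compound 3, `CC1(c2ccc(Nc3nc(Nc4ccccc4)nc(Nc4ccccc4)n3)cc2)NC(=O)c2ccccc2N1`: "not determined" (no result reported)

The account follows one step from compound 1 to compound 4, `CC1(c2ccc(NC(c3ccc(Br)cc3)c3nnnn3C(C)(C)C)cc2)NC(=O)c2ccccc2N1`. In an ADME assay on J774.A1 cells (Mus musculus) for cytotoxicity, read by MTT assay, with a stated time of 72 h (a higher number here means that more compound is tolerated, a lower number that less compound is tolerated), compound 1 has no single number; its entry reads "not determined" (no result reported). Of the two other compounds sharing its core, only compound 2 gives any reading, and that reading is a limit of the assay rather than a number: in this assay compound 2 gives > 400000 nM. Like compound 1, compound 3 has no result in this assay, the entry of compound 3 being "not determined" (no result reported). So the only point of reference is the limit of > 400000 nM in this assay, at which 1 of the 3 values shown sits.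

Compound 4 differs from compound 1 in one place: bromo in place of fluoro on an aromatic carbon. For the measured compounds named here, no step between measured compounds is recorded for this kind of change, and with neither compound 1 nor any neighbour giving a number, no direction can be read from the data. The step from compound 1 to compound 4 in this assay is expected to be none beyond the scatter.

Compound 4 is therefore expected to tolerate roughly 250000 nM, within a range from 60000 nM to 400000 nM, with a fair chance that only a limit is reported.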

Compound 4, half-maximal cytotoxic concentration: 400000 nM
For compound 4 the middle estimate is 1.6-fold (0.20 log units) below the measured one; low and high end bracket the measured number.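

In this assay, for the compounds shown here, compound 4 gives 400000 nM, while compound 1 has no single number, so no step from compound 1 to compound 4 can be read. The compounds shown leave open whether going from 4-fluorophenyl to 4-bromophenyl changes the concentration tolerated in this assay at all.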